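This account rests on a few compounds, and the source may have more. Where it says the series, first, only, none or still open, it means among the compounds named here.

Measured so far in a functional assay on DU-145 cells (Homo sapiens) for inhibition, read by MTT assay, with a stated time of 72 h; a lower number here means a stronger inhibitor, a higher number a weaker inhibitor:
Compound 1 `O=C1C=C(N2CCN(c3ccc(Br)cc3)CC2)C(=O)c2ccccc21`: > 50000 nM
Compound 2 `COc1cccc(N2CCN(C3=CC(=O)c4ccccc4C3=O)CC2)c1`: 15000 nM

For the measured compounds named here, compound 2, at 15000 nM, holds the only exact number in this assay. Compound 1 gives > 50000 nM, which is a limit of the assay and not a number.

The next compound, compound 3 `COc1ccccc1N1CCN(C2=CC(=O)c3ccccc3C2=O)CC1`, has the same atoms as compound 2, joined differently: 2-methoxyphenyl in place of 3-methoxyphenyl on an amine nitrogen in a ring.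

Going by the values given here, only one measured step bears on this change, an at least 3.3-fold lower number from compound 1 to compound 2 (0.52 log units; beyond the scatter), and it lies beyond the scatter. From the compounds shown here alone, that step starts from the limit of > 50000 nM in this assay, at which 1 of the 2 values shown sits, so its full size is unknown. It also exchanges 4-bromophenyl for 3-methoxyphenyl, so it does not measure a change between the two methoxyphenyl groups. It therefore gives only loose guidance, and no step beyond the scatter is expected in either direction in this assay. The expected step is a 1.1-fold lower number from compound 2 to compound 3 (0.03 log units; within the scatter). For compound 3 the estimated value is 14000 nM, with an expected range from 5000 nM to 45000 nM.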

Compound 3, half-maximal inhibitory concentration: 8000 nM
Estimate against measurement, compound 3: 1.8-fold (0.24 log units) above; low and high end bracket the measured number.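

In this assay, 2-methoxyphenyl in place of 3-methoxyphenyl on an amine nitrogen in a ring gives a 1.9-fold lower number from compound 2 to compound 3 (0.27 log units; within the scatter), so this pair does not tell the two methoxyphenyl groups apart. The result also adds a second comparison with the 4-bromophenyl compound, an at least 6.2-fold lower number from compound 1 to compound 3 (0.79 log units; beyond the scatter), which lies beyond the scatter, so both methoxyphenyl groups now stand apart from 4-bromophenyl in the same direction on an otherwise shared core. Compound 1 gives > 50000 nM, which is a limit of the assay and not a number, so the full size of both steps from it remains unknown: the limit of > 50000 nM in this assay, at which 1 of the 3 values shown sits.

The compounds shown leave open whether the methoxy group itself or the loss of bromine accounts for the steps from compound 1, since each step exchanges one for the other in a single move. They also leave open where a plain phenyl group, a chlorophenyl group or an ethoxyphenyl group on the same amine nitrogen would fall relative to compound 2 and compound 3.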